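A Carbamoyl Added to a Series Without Measurable Activity

The source may report more compounds than this note shows. Statements on the series, on what has been measured and on what is new or still open speak of the compounds shown alone.

Three compounds of one shared core were tested in an assay on HL-60 cells for agonist activity at N-formyl peptide receptor 3 (Homo sapiens), read by calcium flux; on this read-out lower numbers stand for an effect already at smaller amounts and higher numbers for an effect only at larger amounts of compound. Compound 1 `COc1cccc(Cc2cc(-c3ccccc3)nn(CC(=O)Nc3ccc(F)cc3)c2=O)c1` gives > 50000 nM, which is a limit of the assay rather than a number. Compound 2 `COc1cccc(Cc2cc(-c3ccc(Cl)cc3)nn(CC(=O)Nc3ccc(F)cc3)c2=O)c1` likewise gives only the limit > 50000 nM. The chloro in place of hydrogen on an aromatic carbon gives a step that the two limits leave unreadable from compound 1 to compound 2. Compound 3 `Cc1cc(Cc2ccccc2)c(=O)n(CC(=O)Nc2ccc(Br)cc2)n1`, built on a different core, also stops at the limit, giving > 50000 nM. Compound 3 thus stands where every value shown stands: the limit of > 50000 nM in this assay, at which 3 of the 3 values shown sit.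

Compound 4 `Cc1cc(Cc2ccc(C(N)=O)cc2)c(=O)n(CC(=O)Nc2ccc(Br)cc2)n1` differs from compound 3 by a single change: carbamoyl in place of hydrogen on an aromatic carbon. Within the data shown here, no measured step involves a carbamoyl, and the one measured step is unreadable, so nothing in the numbers points in either direction. The expectation for compound 4 is that it too remains at the limit, an estimated 50000 nM with a range from 8000 nM to 300000 nM. Estimated this way, the step of a number no higher from compound 3 to compound 4 (the limit leaves the size open) is expected to be none beyond the scatter.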

Compound 4, half-maximal effective concentration: > 50000 nM
Compound 4 was reported as a limit; the forecaster's own chance of this, stated with the estimate: 75%; the middle value sits exactly at the limit.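

Compound 3 and compound 4 both stop at a limit of this assay rather than at a number, so no step can be read between them. The compounds shown leave open whether carbamoyl or any other change on these cores can bring a measurable effect at all.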